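Chloro to trifluoromethyl on the anilide: an expected step

The source may hold more compounds than are shown below. What is called first, only, known or untested is meant among the compounds shown, and "the series" means these compounds.

Measured compounds:
compound 1 `CN(C)C(=O)c1cc2cnc(Nc3ccc(NC(=O)C4(C(=O)Nc5ccc(Cl)cc5)CC4)cc3)nc2n1C1CCCC1`: 24.7%
compound 2 `CN(C)C(=O)c1cc2cnc(Nc3ccc(NC(=O)C4(C(=O)Nc5cccc(C(F)(F)F)c5)CC4)cc3)nc2n1C1CCCC1`: 15.7%

In a functional assay on A549 cells (Homo sapiens) for inhibition, read by CCK-8 assay, with a stated time of 72 h, tested at 1 uM (on this read-out higher numbers stand for more inhibition of growth at the one concentration tested and lower numbers for less inhibition of growth), compound 1 gives 24.7%, the top of the two numbers, yet the step of a number 9 percentage points lower from compound 1 to compound 2 (within the scatter) lies within the scatter, so the two compounds cannot be told apart. Compound 3 `CN(C)C(=O)c1cc2cnc(Nc3ccc(NC(=O)C4(C(=O)Nc5ccc(C(F)(F)F)cc5)CC4)cc3)nc2n1C1CCCC1` differs from compound 1 by trifluoromethyl in place of chloro on an aromatic carbon. For the measured compounds named here, only the step from compound 1 to compound 2 bears on this change, and it stayed within the scatter, so no step beyond the scatter is expected, a number 2.7 percentage points lower from compound 1 to compound 3 (within the scatter). Compound 3 is therefore estimated at 22%, with a range from 8% to 36%.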

Compound 3, percent growth inhibition at one concentration: -25.3%
Estimate against measurement, compound 3: 47.3 percentage points above; measured number below the stated range.
By their numbers in this assay, from the lowest: compound 3; then compounds 2 and 1 (each within the scatter of the next).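

In this assay trifluoromethyl in place of chloro, para to a large group, gives a number 50 percentage points lower from compound 1 to compound 3 (beyond the scatter) and 4-(trifluoromethyl)phenyl in place of 3-(trifluoromethyl)phenyl gives a number 41 percentage points lower from compound 2 to compound 3 (beyond the scatter) with no other change to the molecule. Trifluoromethyl alone therefore does not set the number: compound 2 carries it too and stays within the scatter of compound 1, so among these compounds the group and its place on the ring count together. Nothing at hand accounts for this drop.

As far as these compounds go, whether other groups at this place, such as methoxy, nitrile or an amine, would follow chloro or trifluoromethyl remains open. Also open, from the compounds shown here alone, is whether chloro would show the same dependence on its place on the ring.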